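A few compounds are considered here, and "the series" means these few. Any claim that something is new, unique, unknown or untested is made for them only; others in the source may bear on it.

In a toxicity assay on HepG2 cells (Homo sapiens) for inhibition, read by CellTiter-Glo, with a stated time of 48 h (on this read-out lower numbers stand for stronger inhibition and higher numbers for weaker inhibition), compound 1 `COc1ccc2nc(C)cc(OCC(=O)Nc3cc(C)cc(C)c3)c2c1` gives 20000 nM. Compound 2 `COc1ccc2nc(C)cc(OCC(=O)Nc3cccnc3)c2c1` is weaker: it reaches only a limit in this assay, > 100000 nM, so no exact number is known. The step of an at least 5.0-fold higher number from compound 1 to compound 2 (0.69 log units; beyond the scatter) shows that swapping the aryl group on the amide nitrogen for a pyridine ring costs clearly, as far as the limit of > 100000 nM in this assay, at which 1 of the 2 values shown sits, allows one to tell. Compound 3 `COc1ccc2nc(C)cc(OCC(=O)NNC(=O)c3ccncc3)c2c1` changes that nitrogen again: ((pyridin-4-yl)carbonyl)amino in place of pyridin-3-yl on an amide-type nitrogen. Within the data shown here, no measured step covers this change, so from compound 2 a change a number no higher from compound 2 to compound 3 (the limit leaves the size open) is expected, with a good chance of another limit. Compound 3 is therefore estimated at 100000 nM, within 30000 nM to 300000 nM.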

Compound 3, half-maximal inhibitory concentration: > 100000 nM
Compound 3: a limit, no number; the forecaster's own chance of this, stated with the estimate: 65%; the middle value lies on the limit itself.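

In this assay, ((pyridin-4-yl)carbonyl)amino on the amide-type nitrogen also falls short of 3,5-dimethylphenyl, giving an at least 5.0-fold higher number from compound 1 to compound 3 (0.69 log units; beyond the scatter). The loss is therefore not unique to pyridin-3-yl: it appears with a second, differently attached pyridine group. The step between compound 2 and compound 3 cannot be read, so the two pyridine groups cannot be ranked: the limit of > 100000 nM in this assay, at which 2 of the 3 values shown sit.

On these data alone, what remains open is how a plain phenyl or a benzyl group on this nitrogen would compare with compound 1. Such a group would help show whether the two methyl groups or the ring nitrogen matter more.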